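The compounds below may be only part of what the source reports. "The series", "measured", "known", "first", "only" and "open" are said of these compounds alone.

Of the compounds shown here, three built on one shared core have been measured in an assay on HEK293 cells for inhibition of protein deacetylase HDAC6 (Homo sapiens); a lower number here means a stronger inhibitor, a higher number a weaker inhibitor. Compound 1, with the structure `CCSC(=S)SCC(=O)c1cccc(C(=O)Nc2ccccc2)c1`, gives 517 nM. Compound 2, with the structure `CCSC(=S)SCC(=O)c1ccc(C(=O)NCc2ccccc2)s1`, gives 44 nM. Compound 3, with the structure `CCSC(=S)SCC(=O)c1cccc(CNC(C)=O)c1`, gives 816 nM. Among these three numbers compound 2 stands lowest, and its gaps to compound 1 and to compound 3 both lie beyond the usual scatter of repeated measurements, so compound 2 is the strongest inhibitor of the three.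

Compound 4, with the structure `CCSC(=S)SCC(=O)c1ccc(C(=O)N[C@@H](C)c2ccccc2)s1`, has not yet been measured. It differs from compound 2 in a single place: methyl in place of hydrogen on a saturated chain carbon bound to an amide-type nitrogen and an aromatic carbon. Put another way, the benzyl group on the amide becomes a 1-phenylethyl group. Going by the values given here, no pair of measured compounds shows this particular change, so its effect cannot be read off from the numbers above, and a small change of this kind is as likely to leave the number where it is as to move it. The step from compound 2 to compound 4 is therefore expected to be a 1.4-fold higher number from compound 2 to compound 4 (0.13 log units; within the scatter), which is within the scatter. Compound 4 is estimated to give about 60 nM in this assay, with a plausible range from 20 nM to 200 nM.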

Compound 4, half-maximal inhibitory concentration: 135 nM
Beside the measured number, compound 4's estimate is 2.3-fold (0.35 log units) below it; the measured number falls inside the stated range.
By their numbers in this assay, from the lowest: compound 2; then compound 4; then compounds 1 and 3 (each within the scatter of the next).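

Going by these compounds alone, this pair gives the first direct reading at the saturated chain carbon bound to an amide-type nitrogen and an aromatic carbon, and it shows that this position responds to substitution: in this assay, methyl in place of hydrogen there gives a 3.1-fold higher number from compound 2 to compound 4 (0.49 log units; beyond the scatter) and so a weaker inhibitor. The step is modest, so going from benzyl to 1-phenylethyl lowers the strength of inhibition without removing it. A change of a single carbon atom, with no ring, no hydrogen-bond donor and no hydrogen-bond acceptor added, is thus enough to move the number beyond the scatter, although the compounds shown offer no measurement that explains this.

Still open, from the compounds shown here alone, is whether a larger group on this same carbon, such as ethyl, or a group carrying oxygen, such as hydroxymethyl, would raise the number further or bring it back down. It also remains to be seen how the mirror-image form of the 1-phenylethyl group compares with compound 4, since only one of the two forms appears among these compounds.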